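Cyclopropyl in place of cyano: a clearance estimate

The compounds below may be only part of what the source reports. "The series", "measured", "known", "first", "only" and "open" are said of these compounds alone.

In an in vitro ADME assay on microsomes from liver (Homo sapiens) for pharmacokinetics, read by LC-MS, with a stated time of 10 min, tested at 1 uM (on this read-out higher numbers stand for fast clearance and lower numbers for slow clearance), compound 1 (`CN1C[C@H](C(=O)Nc2ccccc2)[C@@H](c2ccc(/C=C/C(=O)Nc3ccccc3N)cc2)C1`) gives 7 mL/min/kg and compound 2 (`Cc1ccc(NC(=O)[C@H]2CN(C)C[C@@H]2c2ccc(/C=C/C(=O)Nc3ccccc3N)cc2)cc1`) gives 15 mL/min/kg while compound 3 (`CN1C[C@H](C(=O)Nc2ccc(C#N)cc2)[C@@H](c2ccc(/C=C/C(=O)Nc3ccccc3N)cc2)C1`) gives 1 mL/min/kg and so stands lowest of the three. Compound 4 (`CN1C[C@H](C(=O)Nc2ccc(C3CC3)cc2)[C@@H](c2ccc(/C=C/C(=O)Nc3ccccc3N)cc2)C1`) has not yet been measured. It carries cyclopropyl in place of the cyano of compound 3 on an aromatic carbon, para to a large group (cyclopropyl in place of cyano on an aromatic carbon) and the rest of the structure is unchanged.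

Three measured steps fall at this same place. Methyl in place of hydrogen gave a 2.1-fold higher number from compound 1 to compound 2 (0.33 log units; beyond the scatter) and cyano in place of hydrogen gave a 7.0-fold lower number from compound 1 to compound 3 (0.85 log units; beyond the scatter) and both are modest. Cyano in place of methyl gave a 15-fold lower number from compound 2 to compound 3 (1.18 log units; beyond the scatter) and this one is large. Among the measured compounds shown here, no cyclopropyl compound has been measured, so the expectation rests on that last step run backwards, since compound 2 at 15 mL/min/kg also bears a group of carbon only. The step is expected to be large and toward a higher number, estimated as a 15-fold higher number from compound 3 to compound 4 (1.18 log units; beyond the scatter) and so well beyond the scatter. The estimate for compound 4 is 15 mL/min/kg with 6 mL/min/kg to 40 mL/min/kg as the expected range.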

Compound 4, clearance: 12 mL/min/kg
Estimate against measurement, compound 4: 1.3-fold (0.10 log units) above; the range from low to high includes it.
By their numbers in this assay, from the lowest: compound 3; then compounds 1, 4 and 2 (each within the scatter of the next, the first and the last beyond it).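

In this assay, a second group of carbon only at this place lands with the first rather than with the nitrile: cyclopropyl in place of cyano gives a 12-fold higher number from compound 3 to compound 4 (1.08 log units; beyond the scatter), while cyclopropyl in place of methyl gives only a 1.3-fold lower number from compound 2 to compound 4 (0.10 log units; within the scatter). Cyclopropyl in place of hydrogen gives a 1.7-fold higher number from compound 1 to compound 4 (0.23 log units; within the scatter), so compound 4 cannot be told apart from compound 1 either, even though compound 1 and compound 2 lie beyond the scatter of each other. Among the four groups shown on this aromatic carbon, only the cyano of compound 3 stands beyond the scatter of all the others, so the low number goes with that one group and is not shared by hydrogen, methyl or cyclopropyl.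

Nothing measured here says why the cyano group stands apart. From the compounds shown here alone, it also stays open whether other groups on this aromatic carbon, such as an amine, a carboxylic acid or a longer chain, would fall with compound 3 or with compound 1, compound 2 and compound 4.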